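Replacing the bicyclic group on sulfur in a coumarin sulfonate

The compounds below may be only part of what the source reports. "The series", "measured", "known", "first", "only" and "open" are said of these compounds alone.

Compounds measured in an ADME assay on Vero cells (Chlorocebus sabaeus) for cytotoxicity, read by polymerase chain reaction, with a stated time of 18 h; on this read-out higher numbers stand for lower toxicity in this test and lower numbers for higher toxicity in this test:
Compound 1, `O=c1cc(CSc2nc3ccccc3c(=O)[nH]2)c2ccc(OS(=O)(=O)c3ccccc3)cc2o1`: 178000 nM
Compound 2, `O=c1cc(CSc2nc3ccccc3c(=O)[nH]2)c2ccc(OS(=O)(=O)c3ccc(F)cc3)cc2o1`: 30000 nM
Compound 3, `O=c1cc(CSc2nc3ccccc3c(=O)[nH]2)c2ccc(OS(=O)(=O)c3ccc([N+](=O)[O-])cc3)cc2o1`: 117000 nM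

Compound 2 stands lowest of the three in this assay, with a 5.9-fold lower number from compound 1 to compound 2 (0.77 log units; beyond the scatter) separating it from compound 1 and a 3.9-fold higher number from compound 2 to compound 3 (0.59 log units; beyond the scatter) separating it from compound 3. Compound 4, `O=C1CCN=C(SCc2cc(=O)oc3cc(OS(=O)(=O)c4ccc(F)cc4)ccc23)N1`, has not been measured. It differs from compound 2 on the sulfur: a group of 7 heavy atoms (4 carbon, 2 nitrogen, 1 oxygen; one six-membered non-aromatic ring with 2 hetero atoms) in place of a group of 11 heavy atoms (8 carbon, 2 nitrogen, 1 oxygen; one six-membered aromatic ring of carbon only, one six-membered aromatic ring with 2 hetero atoms), on a sulfur.

Within the data shown here, none of the measured steps touches that sulfur; each of them, a 5.9-fold lower number from compound 1 to compound 2 (0.77 log units; beyond the scatter), a 1.5-fold lower number from compound 1 to compound 3 (0.18 log units; within the scatter) and a 3.9-fold higher number from compound 2 to compound 3 (0.59 log units; beyond the scatter), changes only the group on the aromatic carbon of the sulfonate ring. The size and direction of the step from compound 2 to compound 4 therefore cannot be read from the measured pairs, and the estimate for compound 4 rests on compound 2 alone, with a wide range. Compound 4 is expected to give 45000 nM, between 12000 nM and 180000 nM. This expected step, a 1.5-fold higher number from compound 2 to compound 4 (0.18 log units; within the scatter), is set near no change.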

Compound 4, half-maximal cytotoxic concentration: 111000 nM
Compound 4: the middle estimate sits 2.5-fold (0.39 log units) below what was measured; the measured number falls inside the stated range.
By their numbers in this assay, from the lowest: compound 2; then compounds 4, 3 and 1 (each within the scatter of the next).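

The group on the sulfur turns out to matter in this assay: replacing the two-ring group of 11 heavy atoms with the one-ring, non-aromatic group of 7 heavy atoms gives a 3.7-fold higher number from compound 2 to compound 4 (0.57 log units; beyond the scatter). Among these compounds, until now, only the group on the aromatic carbon of the sulfonate ring had been varied, so this is the first sign that a change at the other end of the molecule can also shift the number, here towards lower toxicity in this test. Nothing available explains why this swap has that effect.

Going by these compounds, it remains open whether the same swap would give a step of similar size with hydrogen or nitro in place of fluoro on the sulfonate ring. On these data alone, it is also open how a simple methyl group, a longer alkyl chain or a plain phenyl ring on that sulfur would read.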